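A few compounds are considered here, and "the series" means these few. Any claim that something is new, unique, unknown or untested is made for them only; others in the source may bear on it.

Working notes on the series. The shared core of compound 2 `[O-][n+]1nc(NCOC2CCCCC2)[n+]([O-])c2ccccc21` carries a side chain ending in cyclohexyloxy. In a functional assay on A549 cells (Homo sapiens) for cytotoxicity, read by MTT assay, with a stated time of 72 h (a higher number here means a weaker inhibitor, a lower number a stronger inhibitor), compound 2 gives 1200 nM, the second highest of the three numbers recorded. For the measured compounds named here, compound 3 `CC(OCNc1n[n+]([O-])c2ccccc2[n+]1[O-])c1ccccc1` gives 2810 nM, and compound 1 `COc1ccc2c(c1)[n+]([O-])nc(NCOC(C)c1ccccc1)[n+]2[O-]` gives 220 nM; no single-point step links compound 2 to either, so only the values themselves are noted.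

Compound 4 `CCCCOCNc1n[n+]([O-])c2ccccc2[n+]1[O-]` is the next case: butyl in place of cyclohexyl on an oxygen on a saturated carbon. Going by the values given here, the one measured step, a 13-fold higher number from compound 1 to compound 3 (1.11 log units; beyond the scatter), concerns a methoxy on the aromatic core and not the side chain, so it does not bear on this change. Among the compounds with values here, no measured pair in the set varies the group on the oxygen, and the values of compound 2 and compound 3 differ at both the ring and the side chain at once. With nothing to read from, the expectation is a step no larger than the scatter, with the direction left open.

Compound 4 is therefore estimated at 1500 nM, within 600 nM to 4000 nM, which is expected to mean a 1.3-fold higher number from compound 2 to compound 4 (0.10 log units; within the scatter).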

Compound 4, half-maximal inhibitory concentration: 2320 nM
For compound 4 the middle estimate is 1.5-fold (0.19 log units) below the measured one; low and high end bracket the measured number.
By their numbers in this assay, from the lowest: compound 1; then compounds 2, 4 and 3 (each within the scatter of the next, the first and the last beyond it).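

The group on the oxygen now has its first direct reading: in this assay, butyl in place of cyclohexyl gives a 1.9-fold higher number from compound 2 to compound 4 (0.29 log units; within the scatter). On the shared core, then, the ring of cyclohexyl and the open chain of butyl give numbers that do not separate beyond the scatter, though this rests on a single pair. Nothing measured on these compounds speaks to the reason for this result.

On these data alone, whether the same small step would hold on the methoxy-bearing core of compound 1 remains open. Also open, as far as these compounds go, is how a longer chain such as octyl, or a chain carrying a carboxylic acid or an amine, would read in place of butyl on the same oxygen.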